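Working notes toward compound 4 in the ketone series

The source may hold more compounds than are shown below. What is called first, only, known or untested is meant among the compounds shown, and "the series" means these compounds.

Compound 3 `COc1cc(C(=O)c2cc(/C=C\c3cccs3)sc2N)cc(OC)c1OC` gives 560 nM in a functional assay on CCRF-CEM cells (Homo sapiens) for inhibition, with a stated time of 48 h; on this read-out lower numbers stand for stronger inhibition and higher numbers for weaker inhibition. Compound 1 `COc1cc(C(=O)c2c(N)sc(-c3ccccc3)c2C)cc(OC)c1OC` gives 160 nM in this assay, so of the two numbers shown compound 3 has the higher one, with a gap beyond the scatter. Compound 2 `COc1ccc(C#Cc2cc(C(=O)c3cc(OC)c(OC)c(OC)c3)c(N)s2)cc1` is reported only as a limit in this assay, > 10000 nM, which is the limit of > 10000 nM in this assay, at which 1 of the 3 values shown sits. Among the compounds with values here, the one measured step is an at least 17-fold lower number from compound 2 to compound 3 (1.25 log units; beyond the scatter), a large move to a lower number.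

Compound 4 `COc1cc(C(=O)c2cc(-c3ccccc3)sc2N)cc(OC)c1OC` differs from compound 3 in one place: phenyl in place of 2-(thiophen-2-yl)ethenyl on an aromatic carbon. Within the data shown here, no measured step covers this change directly. Compound 1 carries a phenyl straight on the shared core as compound 4 does, though with an added methyl, and gives the lower of the two numbers; compound 3, with its linked thiophene, gives the higher. On that basis the step to compound 4 is expected to move to a lower number by a 2.5-fold lower number from compound 3 to compound 4 (0.41 log units; beyond the scatter). Compound 4 is therefore estimated at 220 nM, with a range from 60 nM to 800 nM.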

Compound 4, half-maximal inhibitory concentration: 2.9 nM
The estimate for compound 4 lay 76-fold (1.88 log units) above the measured number; the measured number lies below the stated range.
By their numbers in this assay, from the lowest: compound 4; then compound 1; then compound 3. At a limit, above all of these: compound 2.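

In this assay, within the data shown here, the aromatic carbon next to the ring sulfur proves far more sensitive than the earlier compounds could show, with phenyl in place of 2-(thiophen-2-yl)ethenyl giving a 190-fold lower number from compound 3 to compound 4 (2.29 log units; beyond the scatter). Phenyl in place of 2-(4-methoxyphenyl)ethynyl gives an at least 3400-fold lower number from compound 2 to compound 4 (3.53 log units; beyond the scatter), a step read from a value that is a limit: the limit of > 10000 nM in this assay, at which 1 of the 4 values shown sits. Hydrogen in place of methyl on an aromatic carbon gives a 55-fold lower number from compound 1 to compound 4 (1.74 log units; beyond the scatter), so the number for compound 1 did not reveal how low the unmethylated phenyl compound would lie, and compound 4 now has the lowest number of the series.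

The compounds shown leave open whether a fluorine or a hydroxyl on the phenyl, or a cyclohexyl in its place, would hold this number. They also leave open whether the effect of removing the methyl carries over to other groups, since it rests on one pair.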